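The source may hold more compounds than are shown below. What is called first, only, known or untested is meant among the compounds shown, and "the series" means these compounds.

Measured so far in an ADME assay on KB cells (Homo sapiens) for cytotoxicity; a higher number here means that more compound is needed for the effect, a lower number that less compound is needed:

Compound 1 `CCOC(=O)N1[C@@H]2C=C[C@@](OC)(C(=O)c3c2cc(OC)c(OC)c3OCC)N1C(=O)OCC`: > 300 ug/mL, a limit
Compound 2 `COc1cc2c(c(OCc3ccccc3)c1OC)C(=O)[C@]1(OC)C=C[C@H]2N(C(=O)OCC(C)C)N1C(=O)OCC(C)C`: 94 ug/mL
Compound 3 `COc1cc2c(c(OC)c1OC)C(=O)[C@]1(OC)C=C[C@H]2N(C(=O)OCC(C)C)N1C(=O)OCC(C)C`: > 300 ug/mL, a limit

Compound 3 gives no number, only the limit > 300 ug/mL. It sits at the limit of > 300 ug/mL in this assay, at which 2 of the 3 values shown sit. The next compound to be tested is compound 4 `COc1ccc(COc2c(OC)c(OC)cc3c2C(=O)[C@]2(OC)C=C[C@H]3N(C(=O)OCC(C)C)N2C(=O)OCC(C)C)cc1`, which differs from compound 3 by one change: 4-methoxyphenyl in place of hydrogen on a saturated chain carbon bound to an oxygen on an aromatic ring. In words, this is 4-methoxyphenyl in place of hydrogen on a saturated chain carbon bound to an oxygen on an aromatic ring.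

For the measured compounds named here, one measured step bears on this change. It is an at least 3.1-fold higher number from compound 2 to compound 3 (0.50 log units; beyond the scatter), with hydrogen in place of phenyl at that same place. Read backwards, it ties the phenyl to the lower number, and compound 2 is the only compound here with a true value, 94 ug/mL. Going by the values given here, compound 4 also carries a ring at that place, but with a methoxy group on it, and no measured step shows what that addition does. A move towards a lower number in this assay, beyond the scatter, is therefore expected, landing near compound 2. The expected step is an at least 3.5-fold lower number from compound 3 to compound 4 (0.54 log units; beyond the scatter). For compound 4 the estimated value is 85 ug/mL, with an expected range from 30 ug/mL to 240 ug/mL.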

Compound 4, concentration for half-maximal effect: 47.9 ug/mL
The estimate for compound 4 lay 1.8-fold (0.25 log units) above the measured number; the range from low to high includes it.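

In this assay, the change to 4-methoxyphenyl gives an at least 6.2-fold lower number from compound 3 to compound 4 (0.79 log units; beyond the scatter), so the lower number with an aromatic ring at this place no longer rests on the phenyl of compound 2 alone. For the compounds shown here, the methoxy on that ring, an addition no earlier step covered, gives a 2.0-fold lower number from compound 2 to compound 4 (0.29 log units; within the scatter), so the phenyl and 4-methoxyphenyl groups cannot be told apart in this read-out. The step from the hydrogen is a bound and not a full size, since compound 3 stands at a limit: the limit of > 300 ug/mL in this assay, at which 2 of the 4 values shown sit.

The compounds shown leave open whether an aromatic ring is needed at this place at all, or whether a longer saturated chain on the same oxygen would also lower the number. They also leave open how an amine or a carboxylic acid on the ring would read, and whether a substituent other than methoxy would separate itself from the phenyl of compound 2 by more than the scatter.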